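This account rests on a few compounds, and the source may have more. Where it says the series, first, only, none or still open, it means among the compounds named here.

Measured in an ADME assay on MDBK cells (Bos taurus) for cytotoxicity, read by MTT assay, with a stated time of 96 h; a lower number here means that less compound is tolerated, a higher number that more compound is tolerated:
Compound 1 `C=C(C)CNC(=S)Nc1cccc(C(F)(F)F)c1`: > 100000 nM (a limit)
Compound 2 `FC(F)(F)c1cccc(NC(=S)NCc2ccco2)c1`: > 100000 nM (a limit)

Compound 2 has no number on this read-out. Its entry of > 100000 nM is a limit of the assay.

Compound 3 `FC(F)(F)c1cccc(NC(=S)Nc2ccccc2Br)c1` has not yet been measured. Its change from compound 2 is 2-bromophenyl in place of (furan-2-yl)methyl on an amide-type nitrogen. In words, 2-bromophenyl takes the place of (furan-2-yl)methyl on an amide-type nitrogen.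

Among the measured compounds shown here, the one measured step that bears on this change is a step that the two limits leave unreadable from compound 1 to compound 2. It offers no size to carry over. For the measured compounds named here, the series so far shows only (the limit of > 100000 nM in this assay, at which 2 of the 2 values shown sit). Going by the values given here, no measured compound other than compound 3's planned entry carries 2-bromophenyl, so the expectation rests on thin ground.

A modest step towards lower numbers in this assay is expected, with a good chance that compound 3 also returns only a limit. The expected step is an at least 1.4-fold lower number from compound 2 to compound 3 (0.15 log units; that floor lies within the scatter). For compound 3 the estimated half-maximal cytotoxic concentration is 70000 nM, with an expected range of 20000 nM to 100000 nM.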

Compound 3, half-maximal cytotoxic concentration: > 100000 nM
Compound 3 gave a limit, no number (the forecaster's own chance of this, stated with the estimate: 55%); at least 1.4-fold (0.15 log units) between middle value and limit.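

In this assay, no step among compound 1, compound 2 and compound 3 can be read, as each gives only a limit and no number: the limit of > 100000 nM in this assay, at which 3 of the 3 values shown sit.

The compounds shown leave open where the true values lie and whether 2-bromophenyl, (furan-2-yl)methyl and 2-methylprop-2-en-1-yl on the amide-type nitrogen differ at all in cytotoxicity.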